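Cyanopyridinyl exchange on two cores: cytotoxicity notes

This account rests on a few compounds, and the source may have more. Where it says the series, first, only, none or still open, it means among the compounds named here.

Compound 1 `N#C/C=C/c1cc(F)c(Oc2nc(Nc3ccc(C#N)c(F)c3)nc3ccsc23)c(F)c1` and compound 2 `N#C/C=C/c1cc(F)c(Oc2nc(Nc3ccc(C#N)nc3)nc3ccsc23)c(F)c1` share one core; compound 3 `N#C/C=C/c1cc(F)c(Oc2nc(Nc3ccc(C#N)c(F)c3)nc3c2COC3)c(F)c1` and compound 4 `N#C/C=C/c1cc(F)c(Oc2nc(Nc3ccc(C#N)nc3)nc3c2COC3)c(F)c1` share another, and the difference between the two cores is not broken down here. In a toxicity assay on MT4 cells (Homo sapiens) for cytotoxicity, read by MTT assay, with a stated time of 5 days (on this read-out higher numbers stand for lower toxicity in this test and lower numbers for higher toxicity in this test), compound 1 gives 96000 nM, and compound 2 gives 47500 nM. The change between them, (6-cyanopyridin-3-yl in place of 4-cyano-3-fluorophenyl on a nitrogen on an aromatic ring), made a 2.0-fold lower number from compound 1 to compound 2 (0.31 log units; beyond the scatter). Compound 3 gives 243000 nM in this assay, the highest of the three measured numbers. Compound 4 carries the same change on the other core, (6-cyanopyridin-3-yl in place of 4-cyano-3-fluorophenyl on a nitrogen on an aromatic ring), at an identically described place. Among the compounds with values here, the single measured example of this change is a 2.0-fold lower number from compound 1 to compound 2 (0.31 log units; beyond the scatter), and one example on a different core keeps any expectation loose. The step from compound 3 to compound 4 is expected to be similar, a 2.0-fold lower number from compound 3 to compound 4 (0.31 log units; beyond the scatter). Compound 4 is estimated at 120000 nM, with a range of 60000 nM to 250000 nM.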

Compound 4, half-maximal cytotoxic concentration: 243000 nM
Compound 4: middle estimate off by 2.0-fold (0.31 log units), on the low side, and the stated range covers the measured number.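

On the core of compound 3, the exchange of 4-cyano-3-fluorophenyl for 6-cyanopyridin-3-yl gave no change at the digits printed from compound 3 to compound 4 (within the scatter) in this assay. Set beside the step on the other core, the two results do not separate: the same change on two cores in this assay, a 2.0-fold lower number (0.31 log units; beyond the scatter) from compound 1 to compound 2 and no change at the digits printed (within the scatter) from compound 3 to compound 4, 2.0-fold (0.31 log units) apart, within the scatter of two such steps. This fits a change that behaves alike on these two cores, but two pairs in one cell assay do not show that it would carry to a further core, nor do they explain either step.

The compounds shown leave open what an amine or a carboxylic acid in place of the nitrile on the 6-cyanopyridin-3-yl group would give in this assay. Also open, as far as these compounds go, is how the exchange behaves on any third core.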